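The compounds below may be only part of what the source reports. "The series", "measured", "known", "first", "only" and "open" are said of these compounds alone.

Compound 1, `COC(=O)[C@H](CCSC)NC(=O)c1ccc(NCc2cncn2Cc2ccc(Cl)cc2)cc1-c1ccccc1`, is the starting point of this account. In a functional assay on NIH3T3 cells (Mus musculus) (a higher number here means that more compound is needed for the effect, a lower number that less compound is needed), compound 1 gives > 10 uM, which is a limit of the assay rather than a number. Compound 2, `CSCC[C@H](NC(=O)c1ccc(NCc2cncn2Cc2cccc(Cl)c2)cc1-c1ccccc1)C(=O)O`, differs from compound 1 in more than one place. In this assay compound 2 gives > 10 uM, again a limit of the assay and not a number. On the numbers shown, compound 1 stands at the limit of > 10 uM in this assay, at which 2 of the 2 values shown sit, and nothing places it above or below compound 2.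

Compound 3, `COC(=O)[C@H](CCSC)NC(=O)c1ccc(NCc2cncn2Cc2ccc(-c3ccccc3)cc2)cc1-c1ccccc1`, has not yet been measured. It differs from compound 1 in one place: phenyl in place of chloro on an aromatic carbon. For the measured compounds named here, no step between measured compounds in this assay is available, so the size of this change cannot be read from a measured pair. Both measured values are limits, and nothing shows in which direction the change would move the value. Compound 3 is expected to stay near the limit, and the assay is most likely to report only a limit again. The expected step is estimated as a step that the limit leaves unreadable from compound 1 to compound 3. Compound 3 is estimated at 15 uM in this assay, with a range from 4 uM to 60 uM.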

Compound 3, concentration for half-maximal effect: > 10 uM
Compound 3: a limit, no number (the forecaster's own chance of this, stated with the estimate: 75%); the middle value does not contradict the limit.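

In this assay compound 3 gives > 10 uM, which is a limit of the assay and not a number. Compound 1 also sits at a limit, so no step can be read between compound 1 and compound 3: the limit of > 10 uM in this assay, at which 3 of the 3 values shown sit. The compounds shown leave open how far, and in which direction, phenyl in place of chloro moves the value.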